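Inverting the Chain Stereocentre in a Somatostatin Receptor Ligand

This account rests on a few compounds, and the source may have more. Where it says the series, first, only, none or still open, it means among the compounds named here.

Three related compounds have been measured in an assay on isolated protein for binding affinity to somatostatin receptor type 1 (Homo sapiens); a higher number here means weaker binding, a lower number tighter binding. Compound 1 `COC(=O)c1cc(CC(C)CN2CC3CCCCC3C(C(=O)N3CCN(c4ccc([N+](=O)[O-])cc4)CC3)C2)cc(C(=O)OC)c1` gives 1000 nM. Compound 2 `COC(=O)c1cc(CC(C)CN2C[C@@H]3CCCC[C@@H]3[C@H](C(=O)N3CCN(c4ccc([N+](=O)[O-])cc4)CC3)C2)cc(C(=O)OC)c1` gives 398 nM, and compound 3 `COC(=O)c1cc(C[C@@H](C)CN2C[C@@H]3CCCC[C@@H]3[C@H](C(=O)N3CCN(c4ccc([N+](=O)[O-])cc4)CC3)C2)cc(C(=O)OC)c1` gives 437 nM, the second highest of the three numbers. Compound 4 `COC(=O)c1cc(C[C@H](C)CN2C[C@@H]3CCCC[C@@H]3[C@H](C(=O)N3CCN(c4ccc([N+](=O)[O-])cc4)CC3)C2)cc(C(=O)OC)c1` differs from compound 3 only as follows: the two compounds have the same atoms and bonds and differ only in configuration as drawn: 1 of 4 stereo elements differ; a stereocentre at a saturated chain carbon is drawn R in compound 3 and S in compound 4. Among the compounds with values here, the steps that bear on this change are a 2.5-fold lower number from compound 1 to compound 2 (0.40 log units; beyond the scatter), a 2.3-fold lower number from compound 1 to compound 3 (0.36 log units; beyond the scatter) and a 1.1-fold higher number from compound 2 to compound 3 (0.04 log units; within the scatter); the last is the closest comparison, since compound 2 carries no drawn configuration at the chain carbon (the fact that one of compounds 2 and 3 is drawn with a defined configuration and the other without, at the place where they differ), and that step lies within the scatter. Accordingly no step beyond the scatter is expected from a 1.2-fold lower number from compound 3 to compound 4 (0.06 log units; within the scatter). For compound 4 the expected value in this assay is 380 nM, within a range from 150 nM to 950 nM.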

Compound 4, dissociation constant: 933 nM
Compound 4: middle estimate off by 2.5-fold (0.39 log units), on the low side; the range from low to high includes it.
By their numbers in this assay, from the lowest: compounds 2 and 3 (each within the scatter of the next); then compounds 4 and 1 (each within the scatter of the next).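

In this assay the configuration at this saturated chain carbon proves to matter, with a 2.1-fold higher number from compound 3 to compound 4 (0.33 log units; beyond the scatter), so the R form binds more tightly than the S form when nothing else changes: the fact that compounds 3 and 4 differ only in the configuration as drawn. Compound 2, drawn without a configuration there, also lies apart from the S form, with a 2.3-fold higher number from compound 2 to compound 4 (0.37 log units; beyond the scatter), although this comparison is less clean: the fact that one of compounds 2 and 4 is drawn with a defined configuration and the other without, at the place where they differ. The S form gives none of the gain seen in the other defined forms, with a 1.1-fold lower number from compound 1 to compound 4 (0.03 log units; within the scatter), though this step too is qualified: the fact that one of compounds 1 and 4 is drawn with a defined configuration and the other without, at the place where they differ.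

The compounds shown leave open how an ethyl or hydroxyl group at this chain carbon would behave. They also leave open whether the preference for R survives replacing the nitro group with an amine.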